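Adding a Cyano Group to a Sulfur-Bearing Imide

The source may report more compounds than this note shows. Statements on the series, on what has been measured and on what is new or still open speak of the compounds shown alone.

Of the compounds shown here, three have been tested in a functional assay on MCF7 cells (Homo sapiens) for cytotoxicity, read by MTT assay, with a stated time of 72 h; a lower number here means a stronger inhibitor of growth, a higher number a weaker inhibitor of growth. Compound 1, `N#CSc1nc2ccccc2s1`, gives 67600 nM. Compound 2, `[SeH]c1ccnc([SeH])n1`, gives 40000 nM. For compound 3, `O=C1c2ccccc2C(=O)N1CS`, the value > 100000 nM is a limit of the assay and not a measured number. On these data alone, compound 3 therefore sits at the limit of > 100000 nM in this assay, at which 1 of the 3 values shown sits, so its true position on the scale is unknown, other than that it is the weakest-looking of the three.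

Compound 4, `N#CSCN1C(=O)c2ccccc2C1=O`, differs from compound 3 in one place: cyano in place of hydrogen on a sulfur, turning a sulfanylmethyl into a (cyanosulfanyl)methyl. Among the measured compounds shown here, no measured pair shows this change, so its size cannot be read from the data. Compound 1 also carries a cyanosulfanyl group and gives 67600 nM, which is a number rather than a limit. On that slender basis the step from compound 3 to compound 4 is expected to be an at least 1.2-fold lower number from compound 3 to compound 4 (0.09 log units; that floor lies within the scatter), though it could also be none beyond the scatter. Compound 4 is expected to give about 80000 nM, within a range from 30000 nM to 200000 nM.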

Compound 4, concentration for total growth inhibition: > 100000 nM
Compound 4: a limit, no number; the forecaster's own chance of this, stated with the estimate: 45%; middle value at least 1.2-fold (0.09 log units) away from the limit.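

In this assay compound 3 and compound 4 both sit at a limit and not at a measured number, so no step between them can be read: the limit of > 100000 nM in this assay, at which 2 of the 4 values shown sit.

The compounds shown leave open whether cyano in place of hydrogen on a sulfur changes growth inhibition at all, and in which direction.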